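Cyclobutyl for cyclopropyl on the amine of a cyclic sulfonamide

The source may hold more compounds than are shown below. What is called first, only, known or untested is meant among the compounds shown, and "the series" means these compounds.

Compound 1 `CC(C)NC1=NS(=O)(=O)c2cc(F)ccc2N1` gives 43100 nM in a functional assay (aorta) with Rattus norvegicus as the target, with a stated time of 90 min, at 37 degrees C; on this read-out lower numbers stand for an effect already at smaller amounts and higher numbers for an effect only at larger amounts of compound. Compound 2 `C=CCNC1=Nc2cc(Cl)c(Cl)cc2S(=O)(=O)N1` gives 1200 nM. Compound 3 `O=S1(=O)NC(NC2CC2)=Nc2cc(Cl)c(Cl)cc21` gives only a limit of the assay, > 30000 nM.

Compound 3 therefore stands at the edge of what this assay reports (the limit of > 30000 nM in this assay, at which 1 of the 3 values shown sits), with no number of its own. Compound 4 `O=S1(=O)NC(NC2CCC2)=Nc2cc(Cl)c(Cl)cc21` differs from it by cyclobutyl in place of cyclopropyl on an amine nitrogen. Among the compounds with values here, the one measured step that touches this position is an at least 25-fold higher number from compound 2 to compound 3 (1.39 log units; beyond the scatter), a large rise when a ring replaced an open chain on the amine nitrogen. Within the data shown here, no measured step shows how a further ring carbon acts, so a clear direction is not expected; the number for compound 4 is expected to stay near the limit, an at least 1.2-fold lower number from compound 3 to compound 4 (0.07 log units; that floor lies within the scatter). Compound 4 is estimated at 25000 nM, within 6000 nM to 100000 nM.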

Compound 4, half-maximal effective concentration: 12600 nM
For compound 4 the middle estimate is 2.0-fold (0.30 log units) above the measured one; the range from low to high includes it.
By their numbers in this assay, from the lowest: compound 2; then compound 4; then compound 1.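

In this assay the step of an at least 2.3-fold lower number from compound 3 to compound 4 (0.37 log units; beyond the scatter) shows that one more ring carbon on the amine nitrogen brings back a measured number. Yet an 11-fold higher number from compound 2 to compound 4 (1.02 log units; beyond the scatter) shows that cyclobutyl stays well short of what allyl gives at this position. The first step is only a floor, since compound 3 holds a limit of the assay and not a number: the limit of > 30000 nM in this assay, at which 1 of the 4 values shown sits.

Going by these compounds, what cyclopentyl, cyclohexyl or a longer chain such as butyl would give on this amine nitrogen stays open. On these data alone, the true gap between the cyclopropyl and cyclobutyl compounds also stays open.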